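Replacing furan-2-yl with 3-methyl-1H-pyrazol-4-yl in compound 2

This account rests on a few compounds, and the source may have more. Where it says the series, first, only, none or still open, it means among the compounds named here.

Results so far in a functional assay on CWR22R cells (Homo sapiens) for antiproliferative activity, read by CCK-8 assay, with a stated time of 6 days; on this read-out higher numbers stand for weaker inhibition and lower numbers for stronger inhibition
compound 1 `N#Cc1ccc(N2CCc3cc(-c4cccnc4)ccc32)cc1C(F)(F)F` gives "not determined" (no result reported)
compound 2 `CCN(c1ccc(C#N)c(Cl)c1)c1cc(-c2ccco2)ccc1C` gives > 30000 nM
compound 3 `Cc1noc(C)c1-c1cccc2c1CCCN2c1ccc(C#N)c(C(F)(F)F)c1` gives "not determined" (no result reported)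

In this assay compound 2 gives > 30000 nM as a limit of the assay, not a number. Going by the values given here, it is the only one of the three compounds with a reported result. Compound 4 `CCN(c1ccc(C#N)c(Cl)c1)c1cc(-c2c[nH]nc2C)ccc1C` carries 3-methyl-1H-pyrazol-4-yl in place of furan-2-yl on an aromatic carbon. Among the compounds with values here, no measured pair shows what such an exchange does, so the expectation rests on the structural change alone. The expected step is an at least 5.0-fold lower number from compound 2 to compound 4 (0.69 log units; beyond the scatter) toward stronger inhibition, of moderate size. In this assay compound 4 is estimated at 6000 nM with an expected range from 1000 nM to 30000 nM for the measurement.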

Compound 4, half-maximal inhibitory concentration: 5380 nM
Compound 4: middle estimate off by 1.1-fold (0.05 log units), on the high side; measured number inside the range.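

In this assay, exchanging furan-2-yl for 3-methyl-1H-pyrazol-4-yl on this aromatic carbon gives an at least 5.5-fold lower number from compound 2 to compound 4 (0.74 log units; beyond the scatter) and brings a number within the assay's reach at this position. The full size of the step cannot be read because compound 2 stands only at a limit of the assay: the limit of > 30000 nM in this assay, at which 1 of the 4 values shown sits.

The compounds shown leave open whether the second ring nitrogen, the amine hydrogen of the ring or the methyl group carries this step. They also leave open how a pyrazol-4-yl without the methyl group, or a carboxylic acid, would read here.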